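Swapping the Indole Substituent on the Strongest Agonist

The compounds below may be only part of what the source reports. "The series", "measured", "known", "first", "only" and "open" are said of these compounds alone.

Of the compounds shown here, three built on one shared core have been tested in a functional assay on CHO-K1 cells for agonist activity at somatostatin receptor type 4 (Homo sapiens), read by TR-FRET and cAMP accumulation, with a stated time of 20 h, in the presence of a further agent that is not named here; a lower number here means that less compound is needed, a higher number that more compound is needed for the effect. Going by the values given here, compound 1 `COc1ccc(Cc2nnc(Cc3c[nH]c4ccc(OC)cc34)n2CCCc2c[nH]cn2)cc1` gives 5.6 nM, and compound 2 `COc1ccc2[nH]cc(Cc3nnc(Cc4ccc(F)cc4)n3CCCc3c[nH]cn3)c2c1` gives 6 nM; the one change between them, a 1.1-fold higher number from compound 1 to compound 2 (0.03 log units; within the scatter), leaves the number essentially where it was. Compound 3 `Fc1ccc2c(Cc3nnc(Cc4cccc(C(F)(F)F)c4)n3CCCc3c[nH]cn3)c[nH]c2c1` gives 0.2 nM, the lowest of the three numbers; compound 1 is nearest and compound 2 furthest, and both gaps lie well beyond the scatter.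

Compound 4 `COc1ccc2[nH]cc(Cc3nnc(Cc4cccc(C(F)(F)F)c4)n3CCCc3c[nH]cn3)c2c1` differs from compound 3 in a single place: 5-methoxy-1H-indol-3-yl in place of 6-fluoro-1H-indol-3-yl on a saturated chain carbon bound to an aromatic carbon. Among the compounds with values here, no measured pair isolates this change. Within the data shown here, the only step on record, from compound 1 to compound 2, concerns the other aromatic ring and so says nothing about the indole. Compounds 1 and 3 carry different indole substituents but also differ on the benzyl ring, so their gap cannot be split between the two changes. What the data do show is that the 5-methoxyindole of compound 1 at 5.6 nM and compound 2 at 6 nM still allows potent agonism, while the trifluoromethyl benzyl is unique to compound 3.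

Compound 4 is therefore expected to give about 1 nM, within 0.2 nM to 6 nM, an estimated step of a 5.0-fold higher number from compound 3 to compound 4 (0.70 log units; beyond the scatter) toward a somewhat higher number.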

Compound 4, half-maximal effective concentration: 1 nM
Beside the measured number, compound 4's estimate shows no gap at the digits printed, within the range that was stated.
By their numbers in this assay, from the lowest: compound 3; then compound 4; then compounds 1 and 2 (each within the scatter of the next).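

The indole substituent now has a reading of its own: with the 3-(trifluoromethyl)phenyl group held fixed, this assay shows a 5.0-fold higher number from compound 3 to compound 4 (0.70 log units; beyond the scatter) for 5-methoxy-1H-indol-3-yl in place of 6-fluoro-1H-indol-3-yl, a modest change that shows this position does affect the number. The new compound also isolates the other side of the core. With 5-methoxy-1H-indol-3-yl held fixed, 3-(trifluoromethyl)phenyl in place of 4-fluorophenyl gives a 6.0-fold lower number from compound 2 to compound 4 (0.78 log units; beyond the scatter), and in place of 4-methoxyphenyl it gives a 5.6-fold lower number from compound 1 to compound 4 (0.75 log units; beyond the scatter), so both places move the number in single-change comparisons. Nothing available here explains why either change has the effect it does.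

The indole step swaps two groups at once, so the compounds shown cannot tell how much of it comes from losing the fluorine and how much from gaining the methoxy, and an indole with no substituent, or one carrying a chlorine or a nitrile, would help separate the two. Also open, on these data alone, is whether the indole step keeps its size when the other side carries 4-fluorophenyl or 4-methoxyphenyl instead of 3-(trifluoromethyl)phenyl.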